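From 4-chlorobenzyl to 2-chlorobenzyl: working notes

A few compounds are considered here, and "the series" means these few. Any claim that something is new, unique, unknown or untested is made for them only; others in the source may bear on it.

In a functional assay on B16 cells (Mus musculus) for antiproliferative activity, read by MTT assay, with a stated time of 24 h (on this read-out lower numbers stand for stronger inhibition and higher numbers for weaker inhibition), compound 1 `COc1cc(OC)c(-c2coc3cc(OCc4ccc(Br)cc4)ccc3c2=O)cc1OC` gives 1180 nM and compound 2 `COc1cc(OC)c(-c2coc3cc(OCc4ccc(Cl)cc4)ccc3c2=O)cc1OC` gives 2400 nM. Compound 2 therefore holds the higher of the two numbers. Compound 3 `COc1cc(OC)c(-c2coc3cc(OCc4ccccc4Cl)ccc3c2=O)cc1OC` keeps the shared core and carries 2-chlorophenyl in place of 4-chlorophenyl on a saturated chain carbon bound to an oxygen on an aromatic ring. Among the compounds with values here, only one measured step is available: a 2.0-fold higher number from compound 1 to compound 2 (0.31 log units; beyond the scatter), a modest change with chloro in place of bromo on an aromatic carbon. Within the data shown here, it bears only indirectly, since no measured pair shows what moving the chlorine does. Among the measured compounds shown here, with that step as the only guide to size, a modest change in either direction is conceivable, and no direction is favoured. The expected step, a 1.1-fold lower number from compound 2 to compound 3 (0.04 log units; within the scatter), is an estimate with no firm direction. For compound 3 the estimated value is 2200 nM, with an expected range of 1000 nM to 5000 nM.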

Compound 3, half-maximal inhibitory concentration: 4180 nM
For compound 3 the middle estimate is 1.9-fold (0.28 log units) below the measured one; the measured number falls inside the stated range.
By their numbers in this assay, from the lowest: compound 1; then compounds 2 and 3 (each within the scatter of the next).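

In this assay, moving the chlorine from 4-chlorobenzyl to 2-chlorobenzyl reads as a 1.7-fold higher number from compound 2 to compound 3 (0.24 log units; within the scatter), so on this read-out the two chlorine placements cannot be told apart. The position therefore tolerates this move within the resolution of the assay, which the halogen swap alone could not show. Changing 4-bromophenyl to 2-chlorophenyl reads as a 3.5-fold higher number from compound 1 to compound 3 (0.55 log units; beyond the scatter), a modest step that clears the scatter, while the link between compound 2 and compound 3 does not. No measurement accompanies these numbers that could explain them.

As far as these compounds go, how a plain benzyl, a fluoro in place of the chlorine or a longer chain between the oxygen and the ring would read remains open. Also open, from the compounds shown here alone, is whether 2-bromobenzyl would stand apart from 2-chlorobenzyl.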